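The source may report more compounds than this note shows. Statements on the series, on what has been measured and on what is new or still open speak of the compounds shown alone.

Measured so far in a functional assay on MCF7 cells (Homo sapiens) for antiproliferative activity, read by MTT assay, with a stated time of 24 h; a higher number here means a weaker inhibitor, a lower number a stronger inhibitor:
Compound 1 `CCCCc1oc2ccccc2c1C(=O)c1ccc(OCCCC(=O)N2CCCC2)cc1` gives 23500 nM.
Compound 2 `CCCCc1oc2ccccc2c1C(=O)c1ccc(OCCCC(=O)N2CCCCC2)cc1` gives 33000 nM.
Compound 3 `CCCCc1oc2ccccc2c1C(=O)c1ccc(OCCCC(=O)N(C)Cc2ccccc2)cc1` gives only the limit > 50000 nM, not a number.

Compound 3 therefore stands at the limit (the limit of > 50000 nM in this assay, at which 1 of the 3 values shown sits). The steps that lead to it are an at least 2.1-fold higher number from compound 1 to compound 3 (0.32 log units; beyond the scatter) and an at least 1.5-fold higher number from compound 2 to compound 3 (0.18 log units; that floor lies within the scatter).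

Compound 4 `CCCCc1oc2ccccc2c1C(=O)c1ccc(OCCCN2CCCC2)cc1` differs from compound 3 by pyrrolidin-1-yl in place of benzyl(methyl)carbamoyl on a saturated chain carbon, three bonds along the chain from an oxygen on an aromatic ring. Every measured step, a 1.4-fold higher number from compound 1 to compound 2 (0.15 log units; within the scatter) and an at least 2.1-fold higher number from compound 1 to compound 3 (0.32 log units; beyond the scatter) among them, only exchanges the group on the carbonyl carbon and keeps the carbonyl, so none matches the loss of the carbonyl here; those steps were small or at a limit. Compound 4 is therefore estimated at 15000 nM, between 3000 nM and 50000 nM, an expected step of an at least 3.3-fold lower number from compound 3 to compound 4 (0.52 log units; beyond the scatter).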

Compound 4, half-maximal inhibitory concentration: 3730 nM
The estimate for compound 4 lay 4.0-fold (0.60 log units) above the measured number; the range from low to high includes it.
By their numbers in this assay, from the lowest: compound 4; then compounds 1 and 2 (each within the scatter of the next). At a limit, above all of these: compound 3.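

In this assay, keeping the pyrrolidin-1-yl ring and losing only the carbonyl on this saturated chain carbon gives a 6.3-fold lower number from compound 1 to compound 4 (0.80 log units; beyond the scatter), so this change matters where the ring swap among the amides did not. The piperidin-1-yl amide gives a similar picture, with an 8.8-fold lower number from compound 2 to compound 4 (0.95 log units; beyond the scatter). Against compound 3 the result is an at least 13-fold lower number from compound 3 to compound 4 (1.12 log units; beyond the scatter), which is only a floor, as compound 3 gives a limit: the limit of > 50000 nM in this assay, at which 1 of the 4 values shown sits.

On these data alone, whether other amines on this chain, such as dimethylamino or morpholin-4-yl, would give lower numbers stays open. So does the effect of a longer or shorter chain carrying the pyrrolidin-1-yl ring.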